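Exchanging one group on compound 1

The source may report more compounds than this note shows. Statements on the series, on what has been measured and on what is new or still open speak of the compounds shown alone.

Measured so far:
- compound 1 `CN(C)c1ccc(C(=O)N2CCC(NS(=O)(=O)c3cc(S(=O)(=O)c4ccccc4)ccc3C(F)(F)F)CC2)cc1` gives 50000 nM
- compound 2 `O=C(O)c1cccc(S(=O)(=O)N2CCC(NS(=O)(=O)c3cc(S(=O)(=O)c4ccccc4)ccc3C(F)(F)F)CC2)c1` gives 12500 nM
- compound 3 `O=C(O)c1ccc(S(=O)(=O)N2CCC(NS(=O)(=O)c3cc(S(=O)(=O)c4ccccc4)ccc3C(F)(F)F)CC2)cc1` gives 12500 nM

Compound 1 has the highest of these three numbers in a physicochemical assay for solubility (a higher number here means a more soluble compound, a lower number a less soluble compound), and both other compounds lie beyond the scatter from it. The step to compound 4 `CC(C)(C)OC(=O)N1CC[C@H](C(=O)N2CCC(NS(=O)(=O)c3cc(S(=O)(=O)c4ccccc4)ccc3C(F)(F)F)CC2)C1` keeps the shared core and the carbonyl but exchanges the group on that carbonyl carbon (1-(tert-butoxycarbonyl)pyrrolidin-3-yl in place of 4-(dimethylamino)phenyl on a carbonyl carbon) for a new one. Among the measured compounds shown here, no measured step makes this exact exchange. Two measured steps also remove the 4-(dimethylamino)phenyl group, together with its carbonyl (a 4.0-fold lower number from compound 1 to compound 2 (0.60 log units; beyond the scatter)) and (a 4.0-fold lower number from compound 1 to compound 3 (0.60 log units; beyond the scatter)), and both are modest. For the measured compounds named here, the groups entering there are sulfonyl groups carrying a carboxyphenyl, unlike the one in compound 4, so they are only a rough guide. The third step (no change at the digits printed from compound 2 to compound 3 (within the scatter)) concerns a different exchange. Taking compound 3 at 12500 nM as a guide, a modest downward step is expected in this assay with wide uncertainty. An estimated 2.5-fold lower number from compound 1 to compound 4 (0.40 log units; beyond the scatter) is what this expectation amounts to. Compound 4 is estimated at 20000 nM with an expected range of 6000 nM to 50000 nM for now.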

Compound 4, solubility: 25000 nM
Compound 4: the middle estimate sits 1.3-fold (0.10 log units) below what was measured; the measured number falls inside the stated range.
By their numbers in this assay, from the lowest: compounds 2, 3, 4 and 1 (each within the scatter of the next, the first and the last beyond it).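

On a carbonyl carbon whose other neighbours are an amide-type nitrogen in a ring, the 4-(dimethylamino)phenyl group can give way to 1-(tert-butoxycarbonyl)pyrrolidin-3-yl, which has no aromatic ring, more heavy atoms and a defined stereocentre, and this assay still shows only a 2.0-fold lower number from compound 1 to compound 4 (0.30 log units; within the scatter) at this exchange. Among the compounds shown here, the earlier steps from compound 1 also replaced the carbonyl, whereas this one keeps it and changes only the group on it, so it is the first reading of that group alone. Nothing shown explains this result.

As far as these compounds go, whether the same carbonyl carbon would tolerate a pyrrolidine with a free amine, a carboxylic acid or a simple alkyl chain remains open. The mirror-image form of the pyrrolidine in compound 4 is also an open question.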